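Defining the Cyclopropane Stereocentres of a Bile Acid Receptor Agonist

The source may report more compounds than this note shows. Statements on the series, on what has been measured and on what is new or still open speak of the compounds shown alone.

Measured compounds:
compound 1, `CS(=O)(=O)NC(=O)c1ccc(C2CC2c2ccc(OCc3c(-c4c(Cl)cccc4Cl)noc3C3CC3)cc2Cl)cc1` — 90 nM
compound 2, `O=C(NCCS(=O)(=O)O)c1ccc(C2CC2c2ccc(OCc3c(-c4c(Cl)cccc4Cl)noc3C3CC3)cc2Cl)cc1` — 76 nM

In an assay on isolated protein for agonist activity at Bile acid receptor (Homo sapiens), read by FRET (a higher number here means that more compound is needed for the effect, a lower number that less compound is needed), compound 1 gives 90 nM. Going by the values given here, the only comparison at hand is compound 2, which in this assay gives 76 nM; the change a 1.2-fold lower number from compound 1 to compound 2 (0.07 log units; within the scatter) lies within the scatter, so the two numbers cannot be told apart.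

Compound 3, `CS(=O)(=O)NC(=O)c1ccc([C@@H]2C[C@H]2c2ccc(OCc3c(-c4c(Cl)cccc4Cl)noc3C3CC3)cc2Cl)cc1`, is built from compound 1 by the change (the two compounds have the same atoms and bonds; at least one stereo element is drawn with a configuration in one of them and without one in the other: 2 of 2 stereo elements differ; a stereocentre at a saturated ring carbon is drawn without a configuration in compound 1 and R in compound 3; a stereocentre at a saturated ring carbon is drawn without a configuration in compound 1 and R in compound 3). Compound 1 is thus a mixture of stereoisomers, and compound 3 is one defined member of that mixture. Among the compounds with values here, none of the measured steps concerns a stereocentre: the step from compound 1 to compound 2 alters the group on the amide-type nitrogen, which is untouched here, so it gives no guide to the size or direction of this change. For a single isomer drawn out of a mixture, the number is expected either to stay within the scatter or to fall somewhat, should this isomer carry most of the activity. The expected step of a 1.8-fold lower number from compound 1 to compound 3 (0.26 log units; within the scatter) is therefore a modest lowering. Compound 3 is estimated at 50 nM, with a range from 20 nM to 200 nM.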

Compound 3, half-maximal effective concentration: 48 nM
Estimate against measurement, compound 3: 1.0-fold (0.02 log units) above; the measured number falls inside the stated range.
By their numbers in this assay, from the lowest: compounds 3, 2 and 1 (each within the scatter of the next).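

In this assay, the move from the mixture to one defined isomer is a 1.9-fold lower number from compound 1 to compound 3 (0.27 log units; within the scatter), so the two numbers cannot be told apart, and this single isomer clearly carries activity at the level seen for the mixture. Going by these compounds alone, this is the first information on the two saturated ring carbons, since the earlier step between compound 1 and compound 2 touched only the group on the amide-type nitrogen and left the stereocentres as they were. With the same atoms and bonds in both compounds, the comparison is a clean test of one thing, and the only difference to which any gap could be attached is this: the fact that one of compounds 1 and 3 is drawn with a defined configuration and the other without, at the place where they differ

On these data alone, how activity is shared among the other stereoisomers of compound 1 remains open. A difference between isomers can only be judged with at least one further single isomer alongside compound 3. Also open, as far as these compounds go, is whether this defined configuration gives a similar number when the 2-sulfoethyl group of compound 2, or a carboxylic acid, stands in place of the methylsulfonyl amide.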